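Propargyl Thioether to Aryl Ketone Side Chain

The source may report more compounds than this note shows. Statements on the series, on what has been measured and on what is new or still open speak of the compounds shown alone.

Compound 2 `C#CCSc1nnc(-c2cc(OC)c(OC)c(OC)c2)n1N1C(=O)c2ccccc2C1=O` carries a propargylsulfanyl group on the shared core. In a functional assay on A549 cells (Homo sapiens) for cytotoxicity, read by MTT assay, with a stated time of 48 h (on this read-out higher numbers stand for weaker inhibition and lower numbers for stronger inhibition), compound 2 gives > 200000 nM, which is a limit of the assay and not a number. Compound 1 `COc1cc(-c2nnc(SCc3ccccc3Cl)n2N2C(=O)c3ccccc3C2=O)cc(OC)c1OC` instead bears a 2-chlorophenyl on the saturated chain carbon bound to a sulfur. In this assay compound 1 gives > 200000 nM, again a limit. The step that the two limits leave unreadable from compound 1 to compound 2 therefore has no readable size, as the limit of > 200000 nM in this assay, at which 2 of the 2 values shown sit, shows. Compound 3 `COc1cc(-c2nnc(SCC(=O)c3ccc(C)cc3)n2N2C(=O)c3ccccc3C2=O)cc(OC)c1OC` is not yet measured; it differs from compound 2 by (4-methylphenyl)carbonyl in place of ethynyl on a saturated chain carbon bound to a sulfur. Within the data shown here, the only measured step bearing on this change offers no readable size, so no shift beyond the scatter can be expected for compound 3, and a limit again seems the likeliest outcome. Compound 3 is estimated at 200000 nM, with a range from 40000 nM to 400000 nM. The expected step is a number no higher from compound 2 to compound 3 (the limit leaves the size open).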

Compound 3, half-maximal inhibitory concentration: 6760 nM
Compound 3: middle estimate off by 30-fold (1.47 log units), on the high side, outside the stated range (below it).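

This position is not silent after all: in this assay, (4-methylphenyl)carbonyl in place of ethynyl on the saturated chain carbon bound to a sulfur gives an at least 29-fold lower number from compound 2 to compound 3 (1.47 log units; beyond the scatter), and the same group in place of 2-chlorophenyl gives an at least 29-fold lower number from compound 1 to compound 3 (1.47 log units; beyond the scatter). Compound 1 also carries a six-membered aromatic ring of carbon only in this side chain, so in these compounds such a ring alone does not bring a readable value. The step between the two earlier compounds cannot be read, and the two new steps start from values that are limits of the assay, not numbers: the limit of > 200000 nM in this assay, at which 2 of the 3 values shown sit.

As far as these compounds go, what remains open is whether the carbonyl, the methyl or the two together account for the gain. A plain phenylcarbonyl group, or an amide in place of the ketone, would help separate these parts.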